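The source may report more compounds than this note shows. Statements on the series, on what has been measured and on what is new or still open speak of the compounds shown alone.

Three compounds of the shared core have numbers in an assay on HEK293 cells for binding affinity to Gonadotropin-releasing hormone receptor (Homo sapiens); on this read-out lower numbers stand for stronger inhibition and higher numbers for weaker inhibition. Compound 1 `COc1cccc(-c2c(C)n(Cc3c(F)cccc3F)c(=O)n([C@H](C)CNCc3ccccc3)c2=O)c1` gives 75 nM. Compound 2 `COc1cccc(-c2c(C)n(Cc3c(F)cccc3F)c(=O)n([C@H](C)CNCC(C)C)c2=O)c1` gives 190 nM, the second highest of the three, with compound 1 nearest and compound 3 furthest. Compound 3 `COc1cccc(-c2c(C)n(Cc3c(F)cccc3F)c(=O)n([C@@H](C)CNCc3ccccc3F)c2=O)c1` gives 550 nM.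

The step under study goes from compound 2 to compound 4 `COc1cccc(-c2c(C)n(Cc3c(F)cccc3F)c(=O)n([C@H](C)CNCc3cccc(F)c3)c2=O)c1`, where (3-fluorophenyl in place of isopropyl on a saturated chain carbon bound to an amine nitrogen). For the measured compounds named here, two measured steps bear on it. The step of a 2.5-fold higher number from compound 1 to compound 2 (0.40 log units; beyond the scatter), the reverse exchange of phenyl for isopropyl at the same place, so undoing it should lower the number. The step of a 7.3-fold higher number from compound 1 to compound 3 (0.87 log units; beyond the scatter) and the step of a 2.9-fold higher number from compound 2 to compound 3 (0.46 log units; beyond the scatter) show that a fluorine on the benzyl ring, in a different pattern and together with the other changes of compound 3, gave a higher number; the weight of that for 3-fluorophenyl is uncertain. On balance a modest drop below compound 2 is expected, landing near compound 1, as the step of a 1.9-fold lower number from compound 2 to compound 4 (0.28 log units; within the scatter) expresses. Compound 4 is therefore estimated at 100 nM, with a range from 40 nM to 300 nM.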

Compound 4, inhibition constant: 85 nM
Estimate against measurement, compound 4: 1.2-fold (0.07 log units) above; the range from low to high includes it.
By their numbers in this assay, from the lowest: compounds 1 and 4 (each within the scatter of the next); then compound 2; then compound 3.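

In this assay the 3-fluorophenyl group in place of isopropyl gives a 2.2-fold lower number from compound 2 to compound 4 (0.35 log units; beyond the scatter) and so the advantage of phenyl seen in compound 1 also holds with fluoro on that ring. The step of fluoro in place of hydrogen on an aromatic carbon reads a 1.1-fold higher number from compound 1 to compound 4 (0.05 log units; within the scatter) and leaves the number within the usual scatter. The high number of compound 3 therefore does not extend to every fluorine on the benzyl ring, as shown by a 6.5-fold lower number from compound 3 to compound 4 (0.81 log units; beyond the scatter) but compound 3 also carries the opposite configuration at the chain carbon on the aromatic nitrogen, so these two differences stay unseparated.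

No measurement in hand explains any of these steps. Open, on these data alone, is whether a 3-chlorobenzyl or 3-methoxybenzyl group on the amine nitrogen would match compound 4, and what a 2-fluorobenzyl group gives with the configuration of compound 4.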